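The source may report more compounds than this note shows. Statements on the series, on what has been measured and on what is new or still open speak of the compounds shown alone.

Working notes on the series. Three compounds have been run in an assay on isolated protein for inhibition of ribosomal protein S6 kinase alpha-1 (Homo sapiens), read by mobility shift assay, tested at 30 uM; a higher number here means more inhibition at the concentration tested (going by the name of the read-out), a lower number less inhibition. Compound 1 `COC(=O)CCc1c(C)[nH]c(=O)c2c(N)nn(C)c12` gives -5% in this assay. Compound 2 `CC(=O)Nc1nn(C)c2cc(-c3ccccc3)[nH]c(=O)c12` gives 4%. Compound 3 `Cc1cc2nn(-c3ccccc3)c(N)c2c(=O)[nH]1` gives -11%, the lowest of the three numbers; its gap to compound 1 lies within the usual scatter of this assay, while its gap to compound 2 lies beyond it. None of the three shows meaningful inhibition at the concentration tested: all three numbers sit around zero, and nothing in the set so far points to a structural feature that raises inhibition.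

Compound 4 `COc1ccccc1-c1cc2nn(-c3ccccc3)c(N)c2c(=O)[nH]1` is the next compound to be measured. It differs from compound 3 in one place: 2-methoxyphenyl in place of methyl on an aromatic carbon. Within the data shown here, the only precedent for an aromatic ring on the core is compound 2, which carries a phenyl and gives 4%, a number that is itself close to zero. On this basis the step from compound 3 to compound 4 is expected to be small, a number 11 percentage points higher from compound 3 to compound 4 (beyond the scatter), and not beyond the scatter, with no reason in the data to expect inhibition to appear. Compound 4 is estimated at 0% in this assay, with a range from -14% to 14%.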

Compound 4, a percentage reported as inhibition, at one concentration (the size of the read-out at that concentration, not a potency): 3%
Estimate against measurement, compound 4: 3 percentage points below; measured number inside the range.
By their numbers in this assay, from the lowest: compounds 3, 1, 4 and 2 (each within the scatter of the next, the first and the last beyond it).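

Among these compounds, putting 2-methoxyphenyl in place of methyl on the aromatic carbon next to the ring nitrogen gives the first step that can be read: in this assay the change yields a number 14 percentage points higher from compound 3 to compound 4 (beyond the scatter) and is a modest one. Even so, compound 4 stands at 3% and remains close to zero, so a much larger group at this position, bringing an aromatic ring and a hydrogen-bond acceptor, gives no meaningful inhibition at the concentration tested and does not abolish anything either, as compound 3 had no inhibition to lose. No independent measurement bears on what lies behind this step.

Open, going by these compounds, is whether the step belongs to the added ring or to its methoxy group, a question that a plain phenyl at this carbon, set against the 2-methoxyphenyl of compound 4, would separate. Also open, on these data alone, is whether a ring carrying an amine or a carboxylic acid at this position would move the number clear of zero, or whether the position stays flat whatever it holds.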